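This account rests on a few compounds, and the source may have more. Where it says the series, first, only, none or still open, it means among the compounds named here.

Compound 1 `COc1c(F)cccc1N1C(=O)CSC1c1cccc(C(=O)NCCCCc2ccccc2)c1`: 9%
Compound 2 `CC(F)(F)c1cccc(N2C(=O)CSC2c2cccc(C(=O)NCCCCc3ccccc3)c2)c1`: 23%
Compound 3 `COc1ccc(F)cc1N1C(=O)CSC1c1cccc(C(=O)NCCCCc2ccccc2)c1`: 46%

These three share one core and differ only in the ring attached to the amide-type nitrogen in a ring. In a functional assay on HOS cells (Homo sapiens) for inhibition, read by CCK-8 assay, with a stated time of 72 h, tested at 1 uM (on this read-out higher numbers stand for more inhibition at the one concentration tested (going by the name of the read-out) and lower numbers for less inhibition), compound 3 stands highest of the three; the steps of a number 37 percentage points higher from compound 1 to compound 3 (beyond the scatter) and a number 23 percentage points higher from compound 2 to compound 3 (beyond the scatter) show how far it lies above the other two, each beyond the scatter.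

Compound 4 `Cc1cccc(N2C(=O)CSC2c2cccc(C(=O)NCCCCc3ccccc3)c2)c1` has not yet been measured. It carries the change (3-methylphenyl in place of 5-fluoro-2-methoxyphenyl on an amide-type nitrogen in a ring). Going by the values given here, both measured steps at this ring, a number 37 percentage points higher from compound 1 to compound 3 (beyond the scatter) and a number 23 percentage points higher from compound 2 to compound 3 (beyond the scatter), were clearly beyond the scatter, so the ring here is where the numbers move, but no measured compound has a 3-methylphenyl at this spot. For compound 4 a downward step of a number 21 percentage points lower from compound 3 to compound 4 (beyond the scatter) is expected. The estimate for compound 4 is 25%, expected to lie between 5% and 50%.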

Compound 4, a percentage reported as inhibition, at one concentration (the size of the read-out at that concentration, not a potency): 84%
For compound 4 the middle estimate is 59 percentage points below the measured one, outside the stated range (above it).
By their numbers in this assay, from the lowest: compound 1; then compound 2; then compound 3; then compound 4.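

Swapping the ring on the amide-type nitrogen for 3-methylphenyl gives a number 38 percentage points higher from compound 3 to compound 4 (beyond the scatter) and a number 75 percentage points higher from compound 1 to compound 4 (beyond the scatter), so this position can reach far higher inhibition than the methoxy-bearing rings suggested. On the aromatic carbon, the small methyl also gives a number 61 percentage points higher from compound 2 to compound 4 (beyond the scatter), so exchanging 1,1-difluoroethyl for methyl alone moves the number strongly. Nothing measured here explains these steps.

Still open, on these data alone, is how much the methyl itself contributes: a plain phenyl ring, or an ethyl or aminomethyl group on that aromatic carbon, would show this.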